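Removing a Methyl on a Six-Membered Ring: Two Cores Compared

The compounds below may be only part of what the source reports. "The series", "measured", "known", "first", "only" and "open" are said of these compounds alone.

Measured compounds:
Compound 1, `C/C(=N\Nc1nc2ccccc2o1)c1nccnc1C`, gives 900 nM.
Compound 2, `C/C(=N\Nc1nc2ccccc2o1)c1cnccn1`, gives 280 nM.
Compound 3, `C/C(=N\Nc1nc2ccccc2o1)c1ccc(C)nn1`, gives 6270 nM.

All three were tested in a functional assay on cells (Burkitts lymphoma cell, Homo sapiens) for antiproliferative activity, read by MTT assay; a higher number here means a weaker inhibitor, a lower number a stronger inhibitor. Compound 1 and compound 2 differ in one place: hydrogen in place of methyl on an aromatic carbon. That step gave a 3.2-fold lower number from compound 1 to compound 2 (0.51 log units; beyond the scatter). Compound 3 has the same atoms as compound 1, joined differently; the difference between the two cores is not broken down here. Compound 3 gives the highest number of the three.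

Compound 4, `C/C(=N\Nc1nc2ccccc2o1)c1cccnn1`, has not yet been measured. It differs from compound 3 by hydrogen in place of methyl on an aromatic carbon. This is the same kind of change as from compound 1 to compound 2, though not the same: in compound 2 the hydrogen sits ortho to a large group, while in compound 4 it sits para to a large group. Because a 3.2-fold lower number from compound 1 to compound 2 (0.51 log units; beyond the scatter) was modest and clearly beyond the scatter, a step of similar direction is expected here, with some caution since the surroundings of the place differ. For compound 4 the expected step is a 2.5-fold lower number from compound 3 to compound 4 (0.40 log units; beyond the scatter) in this assay. The estimate for compound 4 is 2500 nM, with a range from 900 nM to 7000 nM.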

Compound 4, half-maximal inhibitory concentration: 1300 nM
For compound 4 the middle estimate is 1.9-fold (0.28 log units) above the measured one, within the range that was stated.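

On the second core, taking away the methyl gave a 4.8-fold lower number from compound 3 to compound 4 (0.68 log units; beyond the scatter), the same direction as on the first core. Set side by side, the two steps cannot be told apart in size: the same change on two cores in this assay, a 3.2-fold lower number (0.51 log units; beyond the scatter) from compound 1 to compound 2 and a 4.8-fold lower number (0.68 log units; beyond the scatter) from compound 3 to compound 4, 1.5-fold (0.18 log units) apart, within the scatter of two such steps

The core still counts: with no methyl on either ring, pyridazin-3-yl in place of pyrazin-2-yl gave a 4.6-fold higher number from compound 2 to compound 4 (0.67 log units; beyond the scatter), and two cores alone cannot show that the methyl change would hold on a third core or why it lowers the number in this assay.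

The compounds shown compare only methyl with hydrogen on these rings, so it stays open whether an amine or a methoxy group at the same place would give a lower or a higher number. All four compounds also keep the same methyl on the carbon with a double bond to nitrogen, which leaves open what a longer chain there would do.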